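Swapping amino for formyl on a fluorinated nucleoside

The source may report more compounds than this note shows. Statements on the series, on what has been measured and on what is new or still open speak of the compounds shown alone.

Values in a functional assay on OCI-Ly7 cells (Homo sapiens) for antiproliferative activity, read by WST assay, with a stated time of 3 days; on this read-out higher numbers stand for weaker inhibition and lower numbers for stronger inhibition:
- compound 1 `[N-]=[N+]=Nc1c(F)c(=O)[nH]c(=O)n1[C@@H]1O[C@H](CO)[C@@H](O)[C@H]1O`: 700 nM
- compound 2 `Nc1c(F)c(=O)[nH]c(=O)n1[C@@H]1O[C@H](CO)[C@@H](O)[C@H]1O`: 1300 nM

The measured step, a 1.9-fold higher number from compound 1 to compound 2 (0.27 log units; within the scatter), places compound 2 within the scatter of compound 1. Compound 3 `O=Cc1c(F)c(=O)[nH]c(=O)n1[C@@H]1O[C@H](CO)[C@@H](O)[C@H]1O` differs from compound 2 by formyl in place of amino on an aromatic carbon, with formyl in place of amino on an aromatic carbon. Only the amino-for-azido exchange bears on this change, and that step stayed within the scatter. Formyl itself has not been measured here, so the expectation is loose: no step beyond the scatter is expected, and the estimated step is a 1.2-fold higher number from compound 2 to compound 3 (0.06 log units; within the scatter). For compound 3 the estimated value is 1500 nM, with an expected range of 350 nM to 6500 nM.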

Compound 3, half-maximal inhibitory concentration: 600 nM
The estimate for compound 3 lay 2.5-fold (0.40 log units) above the measured number; low and high end bracket the measured number.
By their numbers in this assay, from the lowest: compounds 3, 1 and 2 (each within the scatter of the next, the first and the last beyond it).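

At this position, ortho to a fluoro group, this assay now shows a step beyond the scatter, a 2.2-fold lower number from compound 2 to compound 3 (0.34 log units; beyond the scatter), though a modest one. Formyl and azido cannot be told apart, with a 1.2-fold lower number from compound 1 to compound 3 (0.07 log units; within the scatter), so amino is separated only from formyl and not from azido. Nothing measured here accounts for the change. The compounds shown leave open how a carboxylic acid, a nitrile or a methyl group would read at this position. They also leave open whether the step from amino to formyl would recur on another core.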